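This account rests on a few compounds, and the source may have more. Where it says the series, first, only, none or still open, it means among the compounds named here.

In a functional assay on HCT-116 cells (Homo sapiens) for inhibition, read by MTT assay, with a stated time of 48 h (on this read-out higher numbers stand for weaker inhibition and lower numbers for stronger inhibition), compound 1 (`COc1ccc(-n2c(SCC(=O)c3ccc(F)cc3)nnc2-c2cc(OC)c(OC)c(OC)c2)cc1`) gives > 60000 nM as a limit of the assay, not a number. Compound 2 (`COc1ccc(-n2c(SCC(=O)c3ccc4ccccc4c3)nnc2-c2cc(OC)c(OC)c(OC)c2)cc1`) gives > 60000 nM as a limit too. Compared with compound 2, compound 3 (`COc1ccc(-n2c(SCC(=O)C3CC3)nnc2-c2cc(OC)c(OC)c(OC)c2)cc1`) carries cyclopropyl in place of naphthalen-2-yl on a carbonyl carbon. Within the data shown here, the only measured step at this place is a step that the two limits leave unreadable from compound 1 to compound 2 and it offers no size to carry forward. Both measured compounds sit at the limit of > 60000 nM in this assay, at which 2 of the 2 values shown sit, and so no clear move in either direction is expected. The expected change is a number no higher from compound 2 to compound 3 (the limit leaves the size open) and this is only an estimate. For compound 3 the estimated value is 60000 nM with an expected range from 20000 nM to 120000 nM and another limit is likely.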

Compound 3, half-maximal inhibitory concentration: > 60000 nM
Compound 3 ended at the assay's limit; the forecaster's own chance of this, stated with the estimate: 75%; the middle value sits exactly at the limit.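

Among these compounds, compound 1, compound 2 and compound 3 all end at an assay limit rather than a number, so no step among them can be read: the limit of > 60000 nM in this assay, at which 3 of the 3 values shown sit. On these data alone, whether 4-fluorophenyl, naphthalen-2-yl and cyclopropyl on the carbonyl carbon differ in inhibition stays open.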